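A few compounds are considered here, and "the series" means these few. Any claim that something is new, unique, unknown or untested is made for them only; others in the source may bear on it.

Measured so far in a functional assay on MCF7 cells (Homo sapiens) for cytotoxicity; on this read-out lower numbers stand for an effect already at smaller amounts and higher numbers for an effect only at larger amounts of compound:
compound 1 `CCCCCn1c(Cc2cc(OC)c(OC)c(OC)c2)nc2c(N)nc(F)nc21` – 286000000 nM
compound 2 `CCCCCCn1c(Cc2cc(OC)c(OC)c(OC)c2)nc2c(N)nc(F)nc21` – 112000000 nM
compound 3 `CC[C@H](C)Cn1c(Cc2cc(OC)c(OC)c(OC)c2)nc2c(N)nc(F)nc21` – 66700000 nM

Within this set of three compound 3 carries the lowest number, though its gap to compound 2 is within the scatter; only its gap to compound 1 is beyond it.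

Compound 4 `C=CCCn1c(Cc2cc(OC)c(OC)c(OC)c2)nc2c(N)nc(F)nc21` is the next member and differs from compound 3 by allyl in place of sec-butyl on a saturated chain carbon bound to an aromatic nitrogen. Going by the values given here, no measured pair shows the same change. Among the compounds with values here, two steps bear on it indirectly: a 4.3-fold lower number from compound 1 to compound 3 (0.63 log units; beyond the scatter) and a 2.6-fold lower number from compound 1 to compound 2 (0.41 log units; beyond the scatter), both giving lower numbers as the chain on the aromatic nitrogen grows or branches, and a 1.7-fold lower number from compound 2 to compound 3 (0.23 log units; within the scatter), which stays within the scatter. Allyl is shorter than butyl, pentyl and sec-butyl alike, so on these three compounds the expectation is a step back toward, or past, the number of compound 1, that is a modest rise rather than a fall. The expected step is a 3.7-fold higher number from compound 3 to compound 4 (0.57 log units; beyond the scatter). The uncertainty is wide, since no chain shorter than butyl has been measured.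

Compound 4 in this assay is therefore estimated at 250000000 nM, with a range of 70000000 nM to 900000000 nM.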

Compound 4, half-maximal effective concentration: 102000000 nM
Beside the measured number, compound 4's estimate is 2.5-fold (0.39 log units) above it, within the range that was stated.
By their numbers in this assay, from the lowest: compounds 3, 4 and 2 (each within the scatter of the next); then compound 1.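

In this assay, going by these compounds alone, allyl in place of sec-butyl on a saturated chain carbon bound to an aromatic nitrogen gives a 1.5-fold higher number from compound 3 to compound 4 (0.18 log units; within the scatter), so this change, which takes 3 heavy atoms in place of 4, adds a double bond and removes the defined stereocentre, produces no step that can be read beyond the scatter. The comparison with the other branch of the series points the same way, with a 1.1-fold lower number from compound 2 to compound 4 (0.04 log units; within the scatter), which places compound 4 level with both compound 2 and compound 3. Only a 2.8-fold lower number from compound 1 to compound 4 (0.45 log units; beyond the scatter) lies beyond the scatter, so compound 4 goes against the reading that the number in this assay falls only as the saturated chain grows or branches, since this unsaturated group stays with compound 2 and compound 3 and apart from compound 1.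

No separate measurement bears on why the unsaturated chain sits with compound 2 and compound 3. Open at this position is whether a longer chain, a terminal amine or a carboxylic acid on the chain would move the number beyond the scatter from compound 3.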